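This account rests on a few compounds, and the source may have more. Where it says the series, first, only, none or still open, it means among the compounds named here.

Working notes on the series.

Compound 3 `Cc1ccc(-c2ccc(CN3CCC(O)(Cn4cnc5c(-c6ccc(CN)cc6)n(C)nc5c4=O)CC3)c(Cl)c2)s1` shows the lowest number of the three measured compounds in an assay on isolated protein for inhibition of ubiquitin carboxyl-terminal hydrolase 7 (Homo sapiens), with stated times of 30 min and 2 h (a lower number here means a stronger inhibitor, a higher number a weaker inhibitor), where compound 3 gives 101 nM. Compound 2 `Cn1nc2c(=O)n(CC3(O)CCN(Cc4ccc(-c5n[nH]c(=O)o5)cc4Cl)CC3)cnc2c1-c1ccc(CN)cc1` gives 171 nM in this assay, and compound 1 `Cn1nc2c(=O)n(CC3(O)CCN(Cc4ccc(-c5ccco5)cc4Cl)CC3)cnc2c1-c1ccc(C(F)(F)F)cc1` gives 530 nM. The gap from compound 3 to compound 2 lies within the scatter, so no order is claimed between them; only the gap to compound 1 is beyond it.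

Compound 4 `Cn1nc2c(=O)n(CC3(O)CCN(Cc4ccc(C5=CCCC5)cc4Cl)CC3)cnc2c1-c1ccc(CN)cc1` is not yet measured. Relative to compound 3 it carries cyclopent-1-en-1-yl in place of 5-methylthiophen-2-yl on an aromatic carbon. Within the data shown here, the one measured step at the same position, a 1.7-fold lower number from compound 2 to compound 3 (0.23 log units; within the scatter), swapped one five-membered aromatic ring for another and stayed within the scatter. Compound 1 also carries a different five-membered aromatic ring there, but it differs from the others at a second place as well, so its value is read only as a value. Among the measured compounds shown here, no measured step exchanges an aromatic ring for a non-aromatic ring of carbon only or removes the single hydrogen-bond acceptor, so the expectation rests on the tolerance seen so far: a step of a 1.6-fold higher number from compound 3 to compound 4 (0.20 log units; within the scatter) is expected, not beyond the scatter. Compound 4 is therefore estimated at 160 nM, with a range from 60 nM to 450 nM.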

Compound 4, half-maximal inhibitory concentration: 76.9 nM
Beside the measured number, compound 4's estimate is 2.1-fold (0.32 log units) above it, and the stated range covers the measured number.
By their numbers in this assay, from the lowest: compounds 4, 3 and 2 (each within the scatter of the next, the first and the last beyond it); then compound 1.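

At this position, on an aromatic carbon para to a large group, a 1.3-fold lower number from compound 3 to compound 4 (0.12 log units; within the scatter) in this assay is read with cyclopent-1-en-1-yl in place of 5-methylthiophen-2-yl, so among these compounds neither an aromatic ring nor a hydrogen-bond acceptor in this group is needed to keep the number in this range. Among these compounds, with the same carbon-only ring in place of the five-membered aromatic ring with 3 hetero atoms, a 2.2-fold lower number from compound 2 to compound 4 (0.35 log units; beyond the scatter) is the first step at this position to pass the scatter, though only modestly. The data shown offer no explanation for either step.

Still open, going by these compounds, is whether the double bond matters, which a saturated cyclopentyl group would test. Also open, on these data alone, is how this position responds to an amine, a carboxylic acid or a longer alkyl chain.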